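The compounds below may be only part of what the source reports. "The series", "measured", "known", "first", "only" and "open" are said of these compounds alone.

Measured compounds:
- compound 1, `NC(=O)c1c(NC(=O)c2ccccc2Cl)sc2c1CCNC2`: 18600 nM
- compound 2, `NC(=O)c1c(NC(=O)c2ccccc2Cl)sc2c1CCN(Cc1ccc([N+](=O)[O-])cc1)C2`: 11400 nM
- compound 3, `NC(=O)c1c(NC(=O)c2ccccc2Cl)sc2c1CCN(C(=S)Nc1ccccc1Br)C2`: 9090 nM

All three values come from a functional assay on HL-60 cells (Homo sapiens) for antiproliferative activity, with a stated time of 24 h; a higher number here means a weaker inhibitor, a lower number a stronger inhibitor. Compound 3 gives the lowest number of the three. The step of a 1.3-fold lower number from compound 2 to compound 3 (0.10 log units; within the scatter) is within the scatter, so the two cannot be ordered; the step of a 2.0-fold lower number from compound 1 to compound 3 (0.31 log units; beyond the scatter) is a modest one that does lie beyond the scatter.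

Compound 4, `Cc1ccccc1NC(=S)N1CCc2c(sc(NC(=O)c3ccccc3Cl)c2C(N)=O)C1`, differs from compound 3 only in this: methyl in place of bromo on an aromatic carbon.

Going by the values given here, none of the measured steps touches this part of the molecule. The steps of a 1.6-fold lower number from compound 1 to compound 2 (0.21 log units; within the scatter) and a 2.0-fold lower number from compound 1 to compound 3 (0.31 log units; beyond the scatter) concern what sits on the amine nitrogen in the ring, and the step of a 1.3-fold lower number from compound 2 to compound 3 (0.10 log units; within the scatter) exchanges one such group for another without leaving the scatter. Together they show that changes on that side of the shared core have moved the number only a little, and they give no direct guide for a swap of bromo for methyl on the aromatic ring of the thiourea part.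

With nothing measured that bears on it, compound 4 is expected to sit close to compound 3, and no step beyond the scatter is expected: a 1.0-fold higher number from compound 3 to compound 4 (0.02 log units; within the scatter). The estimate for compound 4 in this assay is 9500 nM, with a range from 4000 nM to 22000 nM.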

Compound 4, half-maximal inhibitory concentration: 22600 nM
The estimate for compound 4 lay 2.4-fold (0.38 log units) below the measured number, and the stated range ends below it.
By their numbers in this assay, from the lowest: compounds 3, 2, 1 and 4 (each within the scatter of the next, the first and the last beyond it).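

In this assay, going by these compounds alone, the exchange of 2-bromophenyl for 2-methylphenyl gives a 2.5-fold higher number from compound 3 to compound 4 (0.40 log units; beyond the scatter), a modest step that is the first measured at this aromatic carbon and shows that the number responds to a change of a single heavy atom here. The group on the amine nitrogen therefore cannot be read as a whole: with 2-methylphenyl in it, the steps of a 1.2-fold higher number from compound 1 to compound 4 (0.08 log units; within the scatter) and a 2.0-fold higher number from compound 2 to compound 4 (0.30 log units; within the scatter) both remain within the scatter, so this compound cannot be ordered against either of the two, while the 2-bromophenyl group did stand beyond the scatter of the free amine. Nothing available gives a reason for the difference between bromo and methyl at this place.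

The compounds shown leave open whether chloro, fluoro, methoxy or plain hydrogen on this carbon would read closer to bromo or to methyl, and whether a urea in place of the thiourea would keep the number of the bromo compound. They also leave open whether the step between bromo and methyl holds on other cells or after another exposure time.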